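This account rests on a few compounds, and the source may have more. Where it says the series, first, only, none or still open, it means among the compounds named here.

In a physicochemical assay for lipophilicity, using the shake flask method (a higher number here means a more lipophilic compound, a lower number a more polar compound), the record for compound 1 (`CCCC(=O)N1CCC(NC(=O)Nc2ccc(C(F)(F)F)cc2)CC1`) reads "not determined" (no result reported), so the starting point has no number. The nearest anchors are compound 2 (`CCC(C)C(=O)N1CCC(NC(=O)Nc2ccc(C(C)C)cc2)CC1`) at 4.21 and compound 3 (`O=C(Nc1ccc(C(F)(C(F)(F)F)C(F)(F)F)cc1)NC1CCN(C(=O)CC(F)(F)F)CC1`) at 4.89, but each differs from compound 1 in more than one place. Compound 4 (`CCCS(=O)(=O)N1CCC(NC(=O)Nc2ccc(C(F)(F)F)cc2)CC1`) keeps the core of compound 1 and has propylsulfonyl in place of propylcarbonyl on an amine nitrogen in a ring. Going by the values given here, no measured pair shows this change. A modest upward step in this assay is expected, little beyond the scatter, though this remains tentative. The estimated value for compound 4 is 4, with an expected range from 3.4 to 4.6.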

Compound 4, partition coefficient: 3.39
Beside the measured number, compound 4's estimate is 0.61 log units above it; the measured number lies below the stated range.
By their numbers in this assay, from the lowest: compound 4; then compound 2; then compound 3.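

In this assay no step can be read for compound 4: compound 1 has no number, and compound 2 and compound 3 differ from it in more than one place. The compounds shown leave open what propylsulfonyl in place of propylcarbonyl does in this assay on the shared core. No evidence bears on this result.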